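The source may report more compounds than this note shows. Statements on the series, on what has been measured and on what is new or still open speak of the compounds shown alone.

In a functional assay on A-431 cells (Homo sapiens) for inhibition, with a stated time of 72 h (on this read-out lower numbers stand for stronger inhibition and higher numbers for weaker inhibition), compound 1 `CCN(CC)Cc1cc(Cl)c2cccnc2c1O` gives 9330 nM and compound 2 `Oc1c(CN2CCCC2)cc(Cl)c2cccnc12` gives 7410 nM, a difference of a 1.3-fold lower number from compound 1 to compound 2 (0.10 log units; within the scatter). Compound 3 `CC1CCN(Cc2cc(Cl)c3cccnc3c2O)CC1` gives 8710 nM, within the scatter of both. Compound 4 `CC1CCN(Cc2cc(COC(C)C)c3cccnc3c2O)CC1` differs from it as follows: isopropoxymethyl in place of chloro on an aromatic carbon. This puts isopropoxymethyl in place of chloro on an aromatic carbon, para to a hydroxy group. Within the data shown here, the only measured step, a 1.3-fold lower number from compound 1 to compound 2 (0.10 log units; within the scatter), exchanges diethylamino for pyrrolidin-1-yl, and no measured compound replaces chloro. That step therefore gives no real guide to size, and no direction can be drawn from the data, so no shift beyond the scatter is expected, with wide uncertainty. The expected step is a 1.1-fold higher number from compound 3 to compound 4 (0.06 log units; within the scatter). For compound 4 the estimate is 10000 nM, with an expected range of 3500 nM to 30000 nM.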

Compound 4, half-maximal inhibitory concentration: 7080 nM
Beside the measured number, compound 4's estimate is 1.4-fold (0.15 log units) above it; the measured number falls inside the stated range.
By their numbers in this assay, from the lowest: compounds 4, 2, 3 and 1 (each within the scatter of the next).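

Among these compounds, the first measured change at this position, on the aromatic carbon para to a hydroxy group, is isopropoxymethyl in place of chloro, and it gives a 1.2-fold lower number from compound 3 to compound 4 (0.09 log units; within the scatter) in this assay. Going from chloro to isopropoxymethyl, with 5 heavy atoms against 1 and a hydrogen-bond acceptor added, therefore produces no shift beyond the scatter. Nothing available explains why the read-out stays unchanged.

Still open, as far as these compounds go, is whether an aminomethyl group or a carboxylic acid at this position would move the number beyond the scatter. A longer alkoxymethyl chain poses the same question.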